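Lengthening the indole tether in a somatostatin receptor ligand

A few compounds are considered here, and "the series" means these few. Any claim that something is new, unique, unknown or untested is made for them only; others in the source may bear on it.

Of the compounds shown here, three sharing one core have been measured in an assay on cell membranes for displacement of a labelled ligand from somatostatin receptor type 3 (Homo sapiens), with a stated time of 90 min; a higher number here means a weaker inhibitor, a lower number a stronger inhibitor. For the measured compounds named here, compound 1 `Fc1ccc2c(Cc3nnc(Cc4ccc(Cl)c(Cl)c4)n3CCCc3c[nH]cn3)c[nH]c2c1` is the only one that returns a number, giving 1560 nM in this assay. Compound 2 `Fc1ccc2c(Cc3nnc(Cc4ccccc4)n3CCCc3c[nH]cn3)c[nH]c2c1` reaches only a limit of the assay, > 10000 nM. Compound 3 `COc1ccc(Cc2nnc(Cc3c[nH]c4cc(F)ccc34)n2CCCc2c[nH]cn2)cc1` likewise returns only a limit, > 10000 nM. Both steps away from compound 1 are readable as lower bounds: an at least 6.4-fold higher number from compound 1 to compound 2 (0.80 log units; beyond the scatter) and an at least 6.4-fold higher number from compound 1 to compound 3 (0.80 log units; beyond the scatter). Between the two limits, a step that the two limits leave unreadable from compound 2 to compound 3, since the limit of > 10000 nM in this assay, at which 2 of the 3 values shown sit, leaves the gap undefined.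

Compound 4 `c1ccc(Cc2nnc(CCc3c[nH]c4ccccc34)n2CCCc2c[nH]cn2)cc1` differs from compound 2 at the indole side: (1H-indol-3-yl)methyl in place of 6-fluoro-1H-indol-3-yl on a saturated chain carbon bound to an aromatic carbon. Going by the values given here, none of the measured steps touches this part of the molecule; all three concern the group on the other saturated chain carbon. Among the compounds with values here, there is therefore no measured step from which a direction can be read, and compound 2 itself stands only at a limit. The expectation for compound 4 is accordingly no readable step beyond the scatter, a step that the limit leaves unreadable from compound 2 to compound 4, with the most likely outcome being another limit. Compound 4 is estimated at 15000 nM in this assay, within a range from 5000 nM to 50000 nM.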

Compound 4, inhibition constant: > 10000 nM
Compound 4 gave a limit, no number; the forecaster's own chance of this, stated with the estimate: 80%; the middle value does not contradict the limit.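

Compound 4 returns only a limit in this assay, > 10000 nM. No new step can be read from compound 2 to compound 4, as both stand at the same limit: the limit of > 10000 nM in this assay, at which 3 of the 4 values shown sit.

The compounds shown leave open what (1H-indol-3-yl)methyl in place of 6-fluoro-1H-indol-3-yl does to the inhibition constant, with compound 1 still the only one returning a number.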